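Nitro Replaces Methoxy in Compound 3

This account rests on a few compounds, and the source may have more. Where it says the series, first, only, none or still open, it means among the compounds named here.

Three measured compounds share one core and differ only in the group attached to the carbonyl carbon. Compound 1 `CCC(=O)N(C)c1ccc2[nH]c(-c3n[nH]c4ccccc34)cc2n1` bears an ethyl there, and in a functional assay on HL-60 cells (Homo sapiens) for antiproliferative activity, read by MTT assay, with a stated time of 72 h (on this read-out higher numbers stand for weaker inhibition and lower numbers for stronger inhibition), compound 1 gives 6130 nM. Compound 2 `CN(C(=O)c1ccc(Cl)cc1)c1ccc2[nH]c(-c3n[nH]c4ccccc34)cc2n1` carries a 4-chlorophenyl and gives 450 nM. Compound 3 `COc1ccc(C(=O)N(C)c2ccc3[nH]c(-c4n[nH]c5ccccc45)cc3n2)cc1` carries a 4-methoxyphenyl and gives 3320 nM, the second highest of the three numbers. Its nearest neighbour is compound 1, and a 1.8-fold lower number from compound 1 to compound 3 (0.27 log units; within the scatter) lies within the scatter, whereas a 7.4-fold higher number from compound 2 to compound 3 (0.87 log units; beyond the scatter) lies beyond it.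

Compound 4 `CN(C(=O)c1ccc([N+](=O)[O-])cc1)c1ccc2[nH]c(-c3n[nH]c4ccccc34)cc2n1` differs from compound 3 in one place: nitro in place of methoxy on an aromatic carbon. Among the compounds with values here, no measured step exchanges a methoxy for a nitro, so only the comparison of compound 2 with compound 3 bears on it. That comparison, a 7.4-fold higher number from compound 2 to compound 3 (0.87 log units; beyond the scatter), shows that the group on this aromatic carbon can shift the number by a modest amount, and a 14-fold lower number from compound 1 to compound 2 (1.13 log units; beyond the scatter) shows that a substituted phenyl can fall well below the ethyl. The expected step of a 2.8-fold lower number from compound 3 to compound 4 (0.44 log units; beyond the scatter) is therefore a lowering of moderate size, with the nitro outcome placed between those of the methoxy and the chloro. Compound 4 is estimated at 1200 nM, expected to fall within 350 nM to 4000 nM.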

Compound 4, half-maximal inhibitory concentration: 6800 nM
Compound 4: middle estimate off by 5.7-fold (0.75 log units), on the low side; the whole stated range lies below it.
By their numbers in this assay, from the lowest: compound 2; then compounds 3, 1 and 4 (each within the scatter of the next, the first and the last beyond it).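

In this assay, the group on this aromatic carbon does not follow a single trend running from methoxy through nitro to chloro: the change to nitro gives a 2.0-fold higher number from compound 3 to compound 4 (0.31 log units; beyond the scatter) and so places the nitro on the far side of the methoxy from the chloro, not between them. The comparison with the chloro gives a 15-fold higher number from compound 2 to compound 4 (1.18 log units; beyond the scatter), which leaves compound 2 as the only one of the three substituted benzamides whose number stands clearly low. A phenyl ring on the carbonyl carbon therefore does not bring a lower number by itself, since a 1.1-fold higher number from compound 1 to compound 4 (0.05 log units; within the scatter) leaves the 4-nitrophenyl level with the ethyl, as the 4-methoxyphenyl also was.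

Nothing available here accounts for the separate standing of the chloro. Going by these compounds, whether the low number of compound 2 is particular to chloro remains open, and a fluoro, a bromo, an amine or a carboxylic acid on the same aromatic carbon would be needed to show how far it extends.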